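The source may report more compounds than this note shows. Statements on the series, on what has been measured and on what is new or still open speak of the compounds shown alone.

Measured in a functional assay on KB cells (Homo sapiens) for antiproliferative activity, read by sulforhodamine B assay, with a stated time of 3 days; on this read-out higher numbers stand for an effect only at larger amounts of compound and lower numbers for an effect already at smaller amounts:

- compound 1 `CCC1=C(O)c2c(oc(-c3ccc(C)c(C)c3)cc2=O)C(CC)(CC)C1=O`: 35.5 uM
- compound 2 `CCC1=C(O)c2c(oc(-c3ccc(C)c(F)c3)cc2=O)C(CC)(CC)C1=O`: 28.1 uM
- compound 3 `CCC1=C(O)c2c(oc(-c3ccc(OC)cc3C)cc2=O)C(CC)(CC)C1=O`: 20.9 uM

In this assay, compound 3 stands within the scatter of both other compounds. Compound 4 `CCC1=C(O)c2c(oc(-c3ccc(O)c(O)c3)cc2=O)C(CC)(CC)C1=O` carries 3,4-dihydroxyphenyl in place of 4-methoxy-2-methylphenyl on the shared core: 3,4-dihydroxyphenyl in place of 4-methoxy-2-methylphenyl on an aromatic carbon. Among the measured compounds shown here, three measured steps bear on this aryl position: a 1.3-fold lower number from compound 1 to compound 2 (0.10 log units; within the scatter), a 1.7-fold lower number from compound 1 to compound 3 (0.23 log units; within the scatter) and a 1.3-fold lower number from compound 2 to compound 3 (0.13 log units; within the scatter). For the measured compounds named here, all three are small, but no measured compound carries 3,4-dihydroxyphenyl, so they guide the new change only loosely. No step beyond the scatter is expected, and no direction can be favoured. The expected change is a 1.0-fold lower number from compound 3 to compound 4 (0.02 log units; within the scatter). For compound 4 the estimated value is 20 uM, with an expected range of 7 uM to 55 uM.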

Compound 4, concentration for half-maximal effect: 10 uM
The estimate for compound 4 lay 2.0-fold (0.30 log units) above the measured number; measured number inside the range.
By their numbers in this assay, from the lowest: compound 4; then compounds 3, 2 and 1 (each within the scatter of the next).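

In this assay, among the compounds shown here, the steps of a 2.1-fold lower number from compound 3 to compound 4 (0.32 log units; beyond the scatter) and a 2.8-fold lower number from compound 2 to compound 4 (0.45 log units; beyond the scatter) and a 3.6-fold lower number from compound 1 to compound 4 (0.55 log units; beyond the scatter) are modest, but they are the first at this aryl position to lie beyond the scatter. The position therefore responds to at least this change, which the earlier aryl swaps did not show. Nothing given here explains the gain with 3,4-dihydroxyphenyl. The compounds shown leave open whether both hydroxyl groups are needed, as a single one, in 4-hydroxyphenyl or 3-hydroxyphenyl, would test. As far as these compounds go, how an amine or a carboxylic acid would fare on this ring also remains open.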